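Three Flat Chalcones and a Dihydroxyphenyl Newcomer

The compounds below may be only part of what the source reports. "The series", "measured", "known", "first", "only" and "open" are said of these compounds alone.

Three compounds share one core, a trimethoxyphenyl joined through a double bond to a carbonyl, and differ only in the ring on that carbonyl. Compound 1 `COc1cc(OC)c(OC)cc1/C=C/C(=O)c1ccc(C)cc1` gives 2.24 ug/mL in a functional assay on cells (Erythrocyte, Rattus norvegicus) for inhibition, read by hemolysis, with a stated time of 1 h; on this read-out higher numbers stand for weaker inhibition and lower numbers for stronger inhibition. Compound 2 `COc1cc(OC)c(OC)cc1/C=C/C(=O)c1cc(Cl)ccc1O` gives 2.23 ug/mL in this assay, and compound 3 `COc1cc(OC)c(OC)cc1/C=C/C(=O)c1cc(Cc2ccccc2)cc(Cc2ccccc2)c1` gives 2.17 ug/mL. Compound 1 carries the highest of the three numbers, yet the three sit so close that none is separated from another beyond the usual scatter.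

The unmeasured compound 4 `COc1cc(OC)c(OC)cc1/C=C/C(=O)c1ccc(O)cc1O` changes compound 1 as follows: 2,4-dihydroxyphenyl in place of 4-methylphenyl on a carbonyl carbon.

Among the measured compounds shown here, only one measured step speaks to this kind of change. Going a 1.0-fold lower number from compound 1 to compound 2 (0.00 log units; within the scatter) swapped the same 4-methylphenyl for a ring bearing a hydroxyl and a chlorine, and the number did not move. Compound 3, with two benzyl groups on its ring, also gave essentially the same number. Nothing here shows that a hydroxyl on this ring shifts the read-out in either direction, so the expectation for compound 4 is a step in this assay of a 1.0-fold higher number from compound 1 to compound 4 (0.01 log units; within the scatter), no larger than the scatter. Compound 4 is therefore estimated at 2.3 ug/mL, expected to fall between 1.1 ug/mL and 4.8 ug/mL.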

Compound 4, half-maximal inhibitory concentration: 2.37 ug/mL
The estimate for compound 4 lay 1.0-fold (0.01 log units) below the measured number; the measured number falls inside the stated range.
By their numbers in this assay, from the lowest: compounds 3, 2, 1 and 4 (each within the scatter of the next).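

Putting 2,4-dihydroxyphenyl in place of 4-methylphenyl on the carbonyl carbon brings in oxygen atoms and hydrogen-bond donors that the leaving group lacks, yet in this assay this large change in the ring's make-up stays within the scatter (a 1.1-fold higher number from compound 1 to compound 4 (0.02 log units; within the scatter)). The earlier step to compound 2 involved a ring with both a hydroxyl and a chlorine, so it could not show what a ring bearing hydroxyls and no chlorine would do; the step from that ring to the new one also stays within the scatter (a 1.1-fold higher number from compound 2 to compound 4 (0.03 log units; within the scatter)). Compounds 1, 2 and 4 therefore show that this place tolerates a methyl, a chlorine or additional hydroxyls on the ring without any readable shift in this hemolysis-based read-out, and no measurement here accounts for that lack of movement.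

The compounds shown leave open whether a group of another kind on this ring, such as an amine or a carboxylic acid, would produce a step beyond the scatter. They also leave open what would happen if a longer chain took the place of the ring on the carbonyl carbon, or if the shared core itself were altered.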